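A few compounds are considered here, and "the series" means these few. Any claim that something is new, unique, unknown or untested is made for them only; others in the source may bear on it.

The measured compounds:
compound 1, `C/C(=N\O)c1ccc(NC(=O)CSc2nnc(-c3ccccc3)n2-c2ccccc2)cc1`, in a functional assay on the whole organism (strain albino) for inhibition, with Rattus norvegicus as the target, read by paw edema, with stated times of 30 min and 1 h, at a dose of 0.28 mmol/kg by the oral route; a higher number here means more inhibition at the dose given (going by the name of the read-out), a lower number less inhibition: 50%
compound 2, `COc1ccc(-c2nnc(SCC(=O)Nc3ccc(/C(C)=N/O)cc3)n2-c2ccccc2)cc1OC`, in this assay: 57%

Among these two numbers compound 1 stands lowest; its nearest neighbour is compound 2, and the step of a number 7 percentage points higher from compound 1 to compound 2 (within the scatter), brought about by a 3,4-dimethoxyphenyl in place of phenyl on an aromatic carbon, does not leave the scatter. Compound 3, `CC(=O)c1ccc(NC(=O)CSc2nnc(-c3ccccc3)n2-c2ccccc2)cc1`, has not yet been measured in this assay. It differs from compound 1 as follows: a group of 3 heavy atoms (2 carbon, 1 oxygen; no ring) in place of a group of 4 heavy atoms (2 carbon, 1 nitrogen, 1 oxygen; no ring), on an aromatic carbon. For the measured compounds named here, the only measured step concerns a different site of the shared core and was itself within the scatter, so no measured step bears directly on this exchange. With nothing pointing in either direction, compound 3 is expected to give about the same number as compound 1, a step of no change at the digits printed from compound 1 to compound 3 (within the scatter) that stays within the scatter. The estimate for compound 3 is 50%, with a range from 33% to 65%.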

Compound 3, a percentage reported as inhibition, in the whole organism at one dose (the size of the read-out at that dose, not a potency): 41%
Compound 3: the middle estimate sits 9 percentage points above what was measured; the measured number falls inside the stated range.
By their numbers in this assay, from the lowest: compounds 3, 1 and 2 (each within the scatter of the next, the first and the last beyond it).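

For the compounds shown here, compound 3 gives the first reading at the position on the aromatic carbon para to a large group, where acetyl replaces the group of 4 heavy atoms in compound 1. The step of a number 9 percentage points lower from compound 1 to compound 3 (within the scatter) in this assay stays within the scatter, so this exchange, which goes from 1 hydrogen-bond donor to 0 and from 2 hydrogen-bond acceptors to 1, cannot be told apart from no change on this read-out at this single dose. Nothing available here explains the step.

Still open, as far as these compounds go, is whether a group with a different make-up at this position, such as an amine or a carboxylic acid, would move the number beyond the scatter. The compounds shown also leave open whether acetyl would give a similar step on the core of compound 2, which carries the 3,4-dimethoxyphenyl group.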